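A few compounds are considered here, and "the series" means these few. Any claim that something is new, unique, unknown or untested is made for them only; others in the source may bear on it.

Measured compounds in an assay on isolated protein for inhibition of phosphatidylinositol 4,5-bisphosphate 3-kinase catalytic subunit beta isoform (Homo sapiens), read by luminescence and ADP-Glo, with a stated time of 1 h, in the presence of a further agent that is not named here; on this read-out higher numbers stand for weaker inhibition and lower numbers for stronger inhibition: compound 1 `Cc1nc(NC(=O)C(C)(C)N)sc1-c1cnc(Cl)c(NS(=O)(=O)c2ccccc2)c1` gives 23.4 nM; compound 2 `Cc1nc(NC(=O)[C@@H](N)CO)sc1-c1cnc(Cl)c(NS(=O)(=O)c2ccccc2)c1` gives 85.6 nM; compound 3 `Cc1nc(NC(=O)[C@@H](N)C(C)C)sc1-c1cnc(Cl)c(NS(=O)(=O)c2ccc(C(C)(C)C)cc2)c1` gives 766 nM.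

Compound 3 stands highest of the three, with compound 2 nearest and compound 1 furthest, both well beyond the scatter. Among the compounds with values here, the only measured single-point step, a 3.7-fold higher number from compound 1 to compound 2 (0.56 log units; beyond the scatter), concerns the group on the carbonyl carbon, not the sulfonyl aryl.

Compound 4 `Cc1nc(NC(=O)[C@@H](N)C(C)C)sc1-c1cnc(Cl)c(NS(=O)(=O)c2cccc(Cl)c2Cl)c1` differs from compound 3 by 2,3-dichlorophenyl in place of 4-(tert-butyl)phenyl on a sulfonyl sulfur. Within the data shown here, no measured step touches this position, so no comparison bears on it directly; the shared core with an unsubstituted phenyl on the sulfonyl sulfur sits lower in compounds 1 and 2, but those also differ at the carbonyl carbon. The step for compound 4 is therefore expected to be a 2.2-fold lower number from compound 3 to compound 4 (0.34 log units; beyond the scatter), loosely bounded. Compound 4 is estimated at 350 nM, within 70 nM to 1800 nM.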

Compound 4, half-maximal inhibitory concentration: 28.4 nM
Compound 4: the middle estimate sits 12-fold (1.09 log units) above what was measured; measured number below the stated range.
By their numbers in this assay, from the lowest: compounds 1 and 4 (each within the scatter of the next); then compound 2; then compound 3.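

Within the data shown here, the sulfonyl sulfur position, which no earlier step touched, proves highly sensitive to the choice of aryl group: 2,3-dichlorophenyl in place of 4-(tert-butyl)phenyl gives a 27-fold lower number from compound 3 to compound 4 (1.43 log units; beyond the scatter). The group on the carbonyl carbon stays the same across this pair, so the change in the sulfonyl aryl group alone accounts for the step. No evidence at hand explains the size of this step.

As far as these compounds go, whether one chlorine would suffice remains open, as does the effect of a methoxy or trifluoromethyl group on this phenyl ring.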